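This account rests on a few compounds, and the source may have more. Where it says the series, first, only, none or still open, it means among the compounds named here.

In an ADME assay on L6 cells (Rattus norvegicus) for cytotoxicity (a lower number here means a stronger inhibitor, a higher number a weaker inhibitor), compound 1 `CN1CCN(CCCN2CCC3(N(C)C)CC(c4ccccc4)C2C(c2ccccc2)C3)CC1` gives 54500 nM and compound 2 `CN1CCN(CCC(=O)OC2CC3(N4CCCC4)CC(c4ccccc4)C2C(c2ccccc2)C3)CC1` gives 21300 nM while compound 3 `CN1CCN(CCC(=O)N2CCC3(N4CCN(C)CC4)CC(c4ccccc4)C2C(c2ccccc2)C3)CC1` gives 161000 nM as the highest of the three numbers, beyond the scatter from both others. Compound 4 `CN1CCN(CCCN2CCC3(N4CCN(C)CC4)CC(c4ccccc4)C2C(c2ccccc2)C3)CC1` keeps the core of compound 3 and changes one group on an amine nitrogen in a ring, with 3-(4-methylpiperazin-1-yl)propyl in place of (2-(4-methylpiperazin-1-yl)ethyl)carbonyl (3-(4-methylpiperazin-1-yl)propyl in place of (2-(4-methylpiperazin-1-yl)ethyl)carbonyl on an amine nitrogen in a ring). Among the measured compounds shown here, no measured pair isolates this change, so the expectation rests on one indirect comparison. Compound 1 carries the same 3-(4-methylpiperazin-1-yl)propyl group and stands at 54500 nM in this assay as its reading, although it also differs from compound 4 elsewhere on the core. A lower number is therefore expected, with a step beyond the scatter. The expected step of a 3.2-fold lower number from compound 3 to compound 4 (0.51 log units; beyond the scatter) is moderate in size and points downward. The estimate for compound 4 is 50000 nM with an expected range from 18000 nM to 130000 nM in this series.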

Compound 4, half-maximal inhibitory concentration: 47800 nM
For compound 4 the middle estimate is 1.0-fold (0.02 log units) above the measured one; the measured number falls inside the stated range.
By their numbers in this assay, from the lowest: compound 2; then compounds 4 and 1 (each within the scatter of the next); then compound 3.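

In this assay, 3-(4-methylpiperazin-1-yl)propyl in place of (2-(4-methylpiperazin-1-yl)ethyl)carbonyl on the amine nitrogen in a ring gives a 3.4-fold lower number from compound 3 to compound 4 (0.53 log units; beyond the scatter), which isolates this change at this position and shows a step beyond the scatter. With the 3-(4-methylpiperazin-1-yl)propyl group in place, 4-methylpiperazin-1-yl instead of dimethylamino on a saturated ring carbon gives a 1.1-fold lower number from compound 1 to compound 4 (0.06 log units; within the scatter), which lies within the scatter and so shows no change at that carbon. Nothing measured here accounts for either step.

Going by these compounds, whether the propyl-for-carbonyl step carries over to other groups on the saturated ring carbon, such as morpholin-4-yl or a primary amine, stays open. Also open, on these data alone, is how a butyl chain carrying 4-methylpiperazin-1-yl on the same amine nitrogen would read in this assay.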